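Extending the Acetamide of Compound 2 to a Methoxybenzamide

A few compounds are considered here, and "the series" means these few. Any claim that something is new, unique, unknown or untested is made for them only; others in the source may bear on it.

Compound 2 `CC(=O)Nc1ccc2nc(SCC(=O)NCc3ccc(Cl)cc3)sc2c1` was tested in a functional assay on HepG2 cells (Homo sapiens) for cytotoxicity, read by MTT assay, with a stated time of 48 h (a higher number here means a weaker inhibitor, a lower number a stronger inhibitor), where compound 2 gives 6700 nM. Compound 1 `CC(=O)Nc1ccc2nc(SCC(=O)NCc3ccccc3)sc2c1` gives 9200 nM, and the step of a 1.4-fold lower number from compound 1 to compound 2 (0.14 log units; within the scatter) places the two within the scatter, so neither stands apart. Compound 3 `CNC(=O)CSc1nc2ccc(NC(C)=O)cc2s1` reaches only a limit of the assay, > 100000 nM, a point noted as the limit of > 100000 nM in this assay, at which 1 of the 3 values shown sits. The steps of an at least 10-fold higher number from compound 1 to compound 3 (1.03 log units; beyond the scatter) and an at least 14-fold higher number from compound 2 to compound 3 (1.17 log units; beyond the scatter) concern the other amide end, not the carbonyl altered here. Compound 4 `COc1ccccc1C(=O)Nc1ccc2nc(SCC(=O)NCc3ccc(Cl)cc3)sc2c1` differs from compound 2 by 2-methoxyphenyl in place of methyl on a carbonyl carbon. Within the data shown here, no measured step touches this carbonyl carbon, so the step of a 1.3-fold lower number from compound 2 to compound 4 (0.13 log units; within the scatter) is expected to stay within the scatter. Compound 4 is estimated at 5000 nM, between 1500 nM and 20000 nM.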

Compound 4, half-maximal inhibitory concentration: 600 nM
Beside the measured number, compound 4's estimate is 8.3-fold (0.92 log units) above it; measured number below the stated range.
By their numbers in this assay, from the lowest: compound 4; then compounds 2 and 1 (each within the scatter of the next). At a limit, above all of these: compound 3.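

The carbonyl carbon of the acetamido group turns out to be a sensitive position: in this assay, 2-methoxyphenyl in place of methyl gives an 11-fold lower number from compound 2 to compound 4 (1.05 log units; beyond the scatter) and is the only step shown toward a lower number that lies beyond the scatter. The earlier large steps all went toward higher numbers and came from the other amide end. Nothing measured here explains this drop.

On these data alone, it remains open whether a plain phenyl without the methoxy, or a simple propyl chain, on this carbonyl carbon would give the same drop.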